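The source may report more compounds than this note shows. Statements on the series, on what has been measured and on what is new or still open speak of the compounds shown alone.

In an ADME assay on L02 cells (Homo sapiens) for cytotoxicity, read by MTT assay, with a stated time of 24 h (on this read-out higher numbers stand for weaker inhibition and lower numbers for stronger inhibition), compound 1 `COc1cc(/C=C2\CN(S(=O)(=O)c3ccc(F)cc3)C/C(=C\c3cc(OC)c(OC)c(OC)c3)C2=O)cc(OC)c1OC` gives 12100 nM. Compound 2 `COc1cc(/C=C2\CN(S(=O)(=O)c3ccc(NC(C)=O)cc3)C/C(=C\c3cc(OC)c(OC)c(OC)c3)C2=O)cc(OC)c1OC` gives 13600 nM and compound 3 `COc1cc(/C=C2\CN(S(=O)(=O)c3ccc(F)cc3)C/C(=C\c3ccccc3F)C2=O)cc(OC)c1` gives 18500 nM. All three values lie within the scatter of one another, so compound 1 stands level with the other two and is not separated from them.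

Compound 4 `COc1cc(/C=C2\CN(S(=O)(=O)c3ccc(F)cc3)C/C(=C\c3cccc([N+](=O)[O-])c3)C2=O)cc(OC)c1OC` departs from compound 1 in one place: 3-nitrophenyl in place of 3,4,5-trimethoxyphenyl on a double-bonded chain carbon bound to a double-bonded ring carbon.

Within the data shown here, the only measured single-place step is a 1.1-fold higher number from compound 1 to compound 2 (0.05 log units; within the scatter), which is within the scatter. It is acetamido in place of fluoro on an aromatic carbon, a different place from the one changed here, so it bears only indirectly. Among the measured compounds shown here, no measured step exchanges the 3,4,5-trimethoxyphenyl group alone. Compound 1 and compound 3 differ in more than one place, and compound 3 carries no 3,4,5-trimethoxyphenyl group. Even so, compound 3 gives 18500 nM. That lies within the scatter of compound 1 at 12100 nM.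

On this thin evidence, no step beyond the scatter is expected in this assay. The estimated step is a 1.1-fold higher number from compound 1 to compound 4 (0.03 log units; within the scatter). The estimate for compound 4 is 13000 nM, with an expected range from 6000 nM to 28000 nM.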

Compound 4, half-maximal inhibitory concentration: 18800 nM
Beside the measured number, compound 4's estimate is 1.4-fold (0.16 log units) below it; the measured number falls inside the stated range.
By their numbers in this assay, from the lowest: compounds 1, 2, 3 and 4 (each within the scatter of the next).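

Among these compounds, replacing 3,4,5-trimethoxyphenyl with 3-nitrophenyl on a double-bonded chain carbon bound to a double-bonded ring carbon gives, in this assay, a 1.6-fold higher number from compound 1 to compound 4 (0.19 log units; within the scatter), the first measured single-place step at this position. The entering group has fewer heavy atoms and fewer hydrogen-bond acceptors than the leaving one and brings in nitrogen, yet this exchange does not separate compound 4 from compound 1 in this read-out, so the 3,4,5-trimethoxyphenyl group at this one place is not shown to be required for the values seen here. Nothing measured on these compounds explains this outcome.

Neither measured single-place step in this assay reaches beyond the scatter, so the series does not yet show which structural change, if any, can separate compounds in this read-out. Open questions are whether an amine, a carboxylic acid or an unsubstituted phenyl at this place would stay level with compound 1, and what would follow from exchanging the other 3,4,5-trimethoxyphenyl group of compound 1 as well.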